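Swapping phenyl on the carbonyl carbon of compound 3

A few compounds are considered here, and "the series" means these few. Any claim that something is new, unique, unknown or untested is made for them only; others in the source may bear on it.

Measured in a functional assay on Vero cells (Chlorocebus sabaeus) for inhibition; a higher number here means a weaker inhibitor, a lower number a stronger inhibitor:
- compound 1 `COc1cc(/C=C/C(=O)c2cccc(NC(=O)c3ccc(Cl)cc3)c2)ccc1O` gives 3.82 ug/mL
- compound 2 `CCCC(=O)Nc1cccc(C(=O)/C=C/c2ccc(O)c(OC)c2)c1` gives 2.04 ug/mL
- compound 3 `COc1cc(/C=C/C(=O)c2cccc(NC(=O)c3ccccc3)c2)ccc1O` gives 3.47 ug/mL

Compound 3 cannot be separated from the other two compounds, as both of its steps are small: a 1.1-fold lower number from compound 1 to compound 3 (0.04 log units; within the scatter) and a 1.7-fold higher number from compound 2 to compound 3 (0.23 log units; within the scatter). The next structure is compound 4 `CCOC(=O)C(=O)Nc1cccc(C(=O)/C=C/c2ccc(O)c(OC)c2)c1`. The difference is ethoxycarbonyl in place of phenyl on a carbonyl carbon.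

Two measured steps change the group at this same carbonyl carbon: a 1.9-fold lower number from compound 1 to compound 2 (0.27 log units; within the scatter) and a 1.7-fold higher number from compound 2 to compound 3 (0.23 log units; within the scatter). Both stay within the scatter, even though they exchange an aromatic ring for a propyl chain. The chloro step matters less, since it sits on an aromatic carbon. Among the compounds with values here, no measured compound carries ethoxycarbonyl, so these steps support the expectation only indirectly. No step beyond the scatter is expected in this assay, and no direction can be assigned. The expected step is a 1.2-fold lower number from compound 3 to compound 4 (0.06 log units; within the scatter). For compound 4 the estimated value is 3 ug/mL, with an expected range of 1.3 ug/mL to 7 ug/mL.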

Compound 4, half-maximal inhibitory concentration: > 50 ug/mL
Compound 4: only a limit was reported; the forecaster's own chance of this, stated with the estimate: 3%; at least 16-fold (1.22 log units) between middle value and limit.
By their numbers in this assay, from the lowest: compounds 2, 3 and 1 (each within the scatter of the next). At a limit, above all of these: compound 4.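

In this assay, within the data shown here, the exchanges among phenyl, propyl and 4-chlorophenyl on this carbonyl carbon all stayed within the scatter, whereas ethoxycarbonyl gives the first steps beyond it, with an at least 14-fold higher number from compound 3 to compound 4 (1.15 log units; beyond the scatter) and with an at least 24-fold higher number from compound 2 to compound 4 (1.38 log units; beyond the scatter) and with an at least 13-fold higher number from compound 1 to compound 4 (1.11 log units; beyond the scatter) all in the same direction. The reading for compound 4 is a limit and not a number: the limit of > 50 ug/mL in this assay, at which 1 of the 4 values shown sits. Loss of the aromatic ring alone does not match the result, as compound 2, with propyl, also lacks that ring and sits within the scatter of compounds 1 and 3, so the position tolerates a simple chain but not every non-aromatic group.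

The compounds shown leave open whether the result goes with the ethyl ester or with the (ethoxycarbonyl)carbonyl unit as a whole, and a carboxylic acid, a primary amide or a longer alkyl ester on this carbonyl carbon would help separate these. As far as these compounds go, how far compound 4 lies past its limit also stays open, so the size of these steps is known only as a lower bound.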